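Taking one methyl from compound 3: what to expect

The compounds below may be only part of what the source reports. "The series", "measured", "known", "first", "only" and "open" are said of these compounds alone.

Three related compounds sharing one core have been measured so far in a functional assay on DLD-1 cells (Homo sapiens) for cytotoxicity, read by MTT assay (a higher number here means a weaker inhibitor, a lower number a stronger inhibitor), and they give a first sense of scale. Compound 3 (`CCOc1cc(/C=C/C(=O)C(=Cc2ccc(O)c(OC)c2)C(=O)/C=C/c2ccc(O)c(OCC)c2)ccc1O`) gives 9630 nM here, which lies within the usual scatter of compound 1 (`COc1cc(/C=C/C(=O)C(=Cc2ccc(O)c(O)c2)C(=O)/C=C/c2ccc(O)c(OC)c2)ccc1O`) at 17600 nM and is higher than compound 2 (`CCOc1ccc(C=C(C(=O)/C=C/c2ccc(O)c(OC)c2)C(=O)/C=C/c2ccc(O)c(OC)c2)cc1OCC`) at 4120 nM on the same scale.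

The unmeasured compound 4 (`CCOc1cc(/C=C/C(=O)C(=Cc2ccc(O)c(O)c2)C(=O)/C=C/c2ccc(O)c(OCC)c2)ccc1O`) differs from compound 3 by one small edit: hydrogen in place of methyl on an oxygen on an aromatic ring. This turns 4-hydroxy-3-methoxyphenyl into 3,4-dihydroxyphenyl.

Within the data shown here, only one measured step touches that group, and it is a 4.3-fold lower number from compound 1 to compound 2 (0.63 log units; beyond the scatter) with 3,4-diethoxyphenyl in place of 3,4-dihydroxyphenyl. It is an imperfect guide, since it swaps more of the group than the present edit does and it leads away from 3,4-dihydroxyphenyl rather than towards it. Read in reverse, it suggests a higher number, though a smaller shift, as only one methyl leaves here.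

The expected change is a 1.5-fold higher number from compound 3 to compound 4 (0.16 log units; within the scatter) in this assay and it is only a rough expectation. For compound 4 the estimated value is 14000 nM with an expected range from 6500 nM to 30000 nM on present evidence.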

Compound 4, half-maximal inhibitory concentration: 5100 nM
Compound 4: middle estimate off by 2.7-fold (0.44 log units), on the high side; measured number below the stated range.
By their numbers in this assay, from the lowest: compounds 2, 4, 3 and 1 (each within the scatter of the next, the first and the last beyond it).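

In this assay taking the methyl off this oxygen, which turns 4-hydroxy-3-methoxyphenyl into 3,4-dihydroxyphenyl, gives a 1.9-fold lower number from compound 3 to compound 4 (0.28 log units; within the scatter) and so leaves the two groups indistinguishable on this evidence. Among these compounds, this is the first look at one methyl alone: the only earlier step touching this group, a 4.3-fold lower number from compound 1 to compound 2 (0.63 log units; beyond the scatter) and with the whole group exchanged for 3,4-diethoxyphenyl, was beyond the scatter, whereas this single edit is not. Nothing available explains either step, and no measurement beyond these cell results bears on them.

The compounds shown leave open whether a clear shift at this position needs both oxygens to be changed together, since only the step to 3,4-diethoxyphenyl has produced one, and that step was read with methoxy groups on the other two rings rather than the ethoxy groups of compound 4. They also leave open how a longer chain such as butoxy, or an amine, would behave on this ring, as the groups seen here stop at ethoxy and hydroxy.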